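This account rests on a few compounds, and the source may have more. Where it says the series, first, only, none or still open, it means among the compounds named here.

Within the data shown here, all three compounds measured so far share the same core, differing only in the group attached to the oxygen on the saturated carbon of the side chain. Compound 1 `CC(C)=CC[C@@H](OC(=O)CCO)C1=CC(=O)c2c(O)ccc(O)c2C1=O` carries a (2-hydroxyethyl)carbonyl there, compound 2 `CC(C)=CC[C@@H](OC[C@H](C)O)C1=CC(=O)c2c(O)ccc(O)c2C1=O` a 2-hydroxypropyl, and compound 3 `CC(=O)OCCO[C@H](CC=C(C)C)C1=CC(=O)c2c(O)ccc(O)c2C1=O` a 2-acetoxyethyl. In a functional assay on HeLa cells (Homo sapiens) for cytotoxicity, read by MTT assay (a higher number here means a weaker inhibitor, a lower number a stronger inhibitor), compound 1 gives 67600 nM, compound 2 gives 40300 nM, and compound 3 gives 41500 nM. Compound 2 has the lowest of the three numbers, but all three lie within the scatter of one another, so no ordering among them can be read.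

Compound 4 `CC[C@](C)(O)CC(=O)O[C@H](CC=C(C)C)C1=CC(=O)c2c(O)ccc(O)c2C1=O` is not yet measured. Relative to compound 2 the change is (2-hydroxy-2-methylbutyl)carbonyl in place of 2-hydroxypropyl on an oxygen on a saturated carbon, that is, an ether with a hydroxyl becomes an ester with a hydroxyl. The step of a 1.7-fold lower number from compound 1 to compound 2 (0.22 log units; within the scatter) covers the same kind of swap between ester and ether in the reverse direction, and a 1.6-fold lower number from compound 1 to compound 3 (0.21 log units; within the scatter) and a 1.0-fold higher number from compound 2 to compound 3 (0.01 log units; within the scatter) show that further changes among these side chains also stayed within the scatter. No step beyond the scatter is therefore expected for compound 4; the estimated step is a 1.2-fold higher number from compound 2 to compound 4 (0.09 log units; within the scatter). For compound 4 in this assay the estimate is 50000 nM, with a range from 20000 nM to 120000 nM.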

Compound 4, half-maximal inhibitory concentration: 30200 nM
Compound 4: middle estimate off by 1.7-fold (0.22 log units), on the high side; measured number inside the range.
By their numbers in this assay, from the lowest: compounds 4, 2, 3 and 1 (each within the scatter of the next, the first and the last beyond it).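

In this assay this position now gives its first step beyond the scatter, a 2.2-fold lower number from compound 1 to compound 4 (0.35 log units; beyond the scatter) with 1-hydroxy-1-methylpropyl in place of hydroxymethyl on a saturated chain carbon bound to a carbonyl carbon. That step is modest, yet it shows that a change on this chain carbon, within a side chain that keeps its ester and its hydroxyl, can register in this assay. The other two new steps give no such separation, since a 1.3-fold lower number from compound 2 to compound 4 (0.13 log units; within the scatter) and a 1.4-fold lower number from compound 3 to compound 4 (0.14 log units; within the scatter) both stay within the scatter.

As far as these compounds go, whether an amine or a carboxylic acid in place of the hydroxyl on this side chain would move the number further remains open. No measurement shown here explains the one step beyond the scatter.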